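Swapping a para fluoro for dimethylamino on a stilbene sulfonamide

The source may report more compounds than this note shows. Statements on the series, on what has been measured and on what is new or still open speak of the compounds shown alone.

Compound 1 `COc1cc(/C=C/c2ccc(S(N)(=O)=O)cc2)cc(OC)c1`: 16200 nM
Compound 2 `COc1cccc(/C=C/c2ccc(S(N)(=O)=O)cc2)c1`: 554 nM
Compound 3 `NS(=O)(=O)c1ccc(/C=C/c2ccc(F)cc2)cc1`: 29400 nM

Of the compounds shown here, three sharing one core have been tested in a functional assay on HT-29 cells (Homo sapiens) for inhibition; a higher number here means a weaker inhibitor of growth, a lower number a stronger inhibitor of growth. Compound 3 gives the highest number of the three, although its gap to compound 1 is within the scatter, so the two cannot be ranked against each other; compound 2 gives a number far lower than either. Among the compounds with values here, the one measured step, a 29-fold lower number from compound 1 to compound 2 (1.47 log units; beyond the scatter), shows that a single change of a small group on the ring opposite the sulfonamide can move the result a long way.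

Compound 4 `CN(C)c1ccc(/C=C/c2ccc(S(N)(=O)=O)cc2)cc1` is not yet measured. It differs from compound 3 in one place: dimethylamino in place of fluoro on an aromatic carbon. Within the data shown here, no measured step covers a change of this kind, so the only guide is that a small change on this ring produced a large step between compound 1 and compound 2, and that compound 3 sits at the weak end. A change of this size is therefore expected to move the number rather than leave it within the scatter, and the more likely direction is downward, toward stronger inhibition. For compound 4 the expected result is 4000 nM, within 400 nM to 40000 nM, a step of a 7.4-fold lower number from compound 3 to compound 4 (0.87 log units; beyond the scatter).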

Compound 4, concentration for 50% growth inhibition: 30800 nM
Compound 4: middle estimate off by 7.7-fold (0.89 log units), on the low side; the range from low to high includes it.
By their numbers in this assay, from the lowest: compound 2; then compounds 1, 3 and 4 (each within the scatter of the next).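

In this assay, dimethylamino in place of fluoro on an aromatic carbon para to a large group gives a 1.0-fold higher number from compound 3 to compound 4 (0.02 log units; within the scatter) so these two groups cannot be told apart at this position, even though dimethylamino brings more heavy atoms and a hydrogen-bond acceptor. This shows that exchanging one group on this ring need not move the result: the earlier 29-fold lower number from compound 1 to compound 2 (1.47 log units; beyond the scatter) came from hydrogen in place of methoxy, a different change at a different place, and its size does not carry over to this position. Nothing at hand explains why this exchange leaves the result within the scatter.

Two groups at one position cannot show whether this place is insensitive in general, so a primary amine or a hydroxyl here, or a methoxy moved here from elsewhere on the ring, could still give a different result. On these data alone, the sulfonamide is also the same in all four compounds, so what a carboxylic acid in its place would do remains open.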